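Swapping Chloro for Phenylsulfanyl on a Scaffold with Low Numbers in This Assay

The compounds below may be only part of what the source reports. "The series", "measured", "known", "first", "only" and "open" are said of these compounds alone.

Compound 1, `Clc1ncnc2c1ncn2Cc1ccccc1`: in an assay on isolated protein for inhibition of Ca2+/calmodulin-dependent protein kinase II (CaM kinase II) (Rattus norvegicus), tested at 30 uM (a lower number here means less inhibition, a higher number more inhibition at the concentration tested (going by the name of the read-out)), compound 1 gives 7%.
Compound 2, `Fc1ccc(Cn2cnc3c(Cl)ncnc32)cc1`: compound 2 gives 0%.
Compound 3, `Nc1ncnc2ncn(Cc3ccc(F)cc3)c12`: compound 3 gives 8%.

Compound 2 shows the lowest of the three numbers, yet compound 1 and compound 3 both lie within the scatter of it, and none of the three can be set apart from the others. Within the data shown here, the only step measured between two compounds that differ in one place is a number 7 percentage points lower from compound 1 to compound 2 (within the scatter), and it lies within the scatter.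

Compound 4, `Fc1ccc(Cn2cnc3c(Sc4ccccc4)ncnc32)cc1`, differs from compound 2 by phenylsulfanyl in place of chloro on an aromatic carbon. Among the measured compounds shown here, no measured step involves a change of this kind, and the one step that was measured gives no direct guide to it. All three measured compounds sit near the bottom of the scale. Compound 4 is therefore expected to stay close to compound 2, with an expected step of a number 8 percentage points higher from compound 2 to compound 4 (within the scatter). The estimate for compound 4 in this assay is 8%, within a range from -5% to 30%.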

Compound 4, a percentage reported as inhibition, at one concentration (the size of the read-out at that concentration, not a potency): 0%
Estimate against measurement, compound 4: 8 percentage points above, within the range that was stated.
By their numbers in this assay, from the lowest: compounds 2, 4, 1 and 3 (each within the scatter of the next).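

Putting phenylsulfanyl in place of chloro on the aromatic carbon next to the ring nitrogen gives, in this assay, no change at the digits printed from compound 2 to compound 4 (within the scatter). Among these compounds, this is the first look at a change at this position, and it shows that a group of 7 heavy atoms with its own six-membered aromatic ring, replacing a single chlorine, leaves the number at the bottom of the scale, with compound 4 at 0%. Nothing available explains this result.

Since compound 2 already gives 0%, this pair cannot show whether the position matters for inhibition at all, only that this one replacement brings none into view. As far as these compounds go, whether a different group here, such as a carboxylic acid or a longer chain, would give a number clear of the scatter remains open.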